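The source may report more compounds than this note shows. Statements on the series, on what has been measured and on what is new or still open speak of the compounds shown alone.

Measured so far:
- compound 1 `Nc1nc2cc(-c3nn(CCCC(=O)NO)c4ncnc(N)c34)ccc2o1`: 19600 nM
- compound 2 `Nc1ncnc2c1c(-c1cnc3[nH]ccc3c1)nn2CCCCCC(=O)NO`: 63700 nM

In a functional assay on HCT-116 cells (Homo sapiens) for inhibition, read by MTT assay, with a stated time of 72 h (on this read-out lower numbers stand for stronger inhibition and higher numbers for weaker inhibition), compound 1 stands lowest of the two at 19600 nM, and compound 2 gives 63700 nM, a gap that lies beyond the usual scatter. Compound 3 `Nc1nc2cc(-c3nn(CCCCCCCCCC(=O)NO)c4ncnc(N)c34)ccc2o1` keeps the core of compound 1 and differs at one place: 6-(hydroxycarbamoyl)hexyl in place of hydroxycarbamoyl on a saturated chain carbon, three bonds along the chain from an aromatic nitrogen. This puts 6-(hydroxycarbamoyl)hexyl in place of hydroxycarbamoyl on a saturated chain carbon, three bonds along the chain from an aromatic nitrogen. Within the data shown here, no measured pair isolates a change of chain alone, so the support is weak. A moderate step to a lower number in this assay is expected, more than the scatter but with no large gain. The expected change is a 3.3-fold lower number from compound 1 to compound 3 (0.51 log units; beyond the scatter). The estimate for compound 3 is 6000 nM, with an expected range of 1000 nM to 30000 nM.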

Compound 3, half-maximal inhibitory concentration: 23100 nM
For compound 3 the middle estimate is 3.9-fold (0.59 log units) below the measured one; the measured number falls inside the stated range.
By their numbers in this assay, from the lowest: compounds 1 and 3 (each within the scatter of the next); then compound 2.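

In this assay, 6-(hydroxycarbamoyl)hexyl in place of hydroxycarbamoyl on a saturated chain carbon, three bonds along the chain from an aromatic nitrogen, gives a 1.2-fold higher number from compound 1 to compound 3 (0.07 log units; within the scatter). On the core of compound 1, this position therefore carries the added chain with no difference beyond the scatter, and this single pair gives no sign that the read-out follows chain length. Nothing at hand explains this result.

Going by these compounds, the pair fixes only the two ends of this change, so the effect of a chain of intermediate length, or of a still longer chain, remains open. Also open, on these data alone, is whether a carboxylic acid or an amine at the chain end, in place of hydroxycarbamoyl, would keep the number at this level.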